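The compounds below may be only part of what the source reports. "The series", "measured", "known", "first", "only" and "open" are said of these compounds alone.

Compound 1 `Nc1cccc(C#CC#Cc2cn([C@H]3C[C@H](O)[C@@H](CO)O3)c(=O)[nH]c2=O)c1` is the point of departure. In an ADME assay on HEL cells (Homo sapiens) for cytotoxicity, read by microscopy (a lower number here means that less compound is tolerated, a higher number that more compound is tolerated), compound 1 reaches only a limit, > 100000 nM. Two companions share its core. Compound 2 `O=c1[nH]c(=O)n([C@H]2C[C@H](O)[C@@H](CO)O2)cc1C#CC#Cc1ccc(OC(F)(F)F)cc1` gives a number in this assay, 100000 nM. Compound 3 `O=c1[nH]c(=O)n([C@H]2C[C@H](O)[C@@H](CO)O2)cc1C#CC#CCC1CCCC1` again stops at a limit in this assay, > 100000 nM. For the measured compounds named here, the single measured step that alters one place, a step that the two limits leave unreadable from compound 1 to compound 3, puts cyclopentylmethyl in place of 3-aminophenyl on a triple-bonded carbon, and its size cannot be read because both ends are limits. What the set does show is plain: the limit of > 100000 nM in this assay, at which 2 of the 3 values shown sit.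

The compound still to be measured is compound 4 `O=c1[nH]c(=O)n([C@H]2C[C@H](O)[C@@H](CO)O2)cc1C#CC#CC1CC1`, which differs from compound 1 by cyclopropyl in place of 3-aminophenyl on a triple-bonded carbon. The step from compound 1 to compound 3 bears on this change, since it alters the same triple-bonded carbon, yet it carries no readable size. Nothing among the shown numbers points to a move beyond the scatter in this assay in either direction, and the most likely outcome is another limit. Compound 4 is therefore expected to sit near 100000 nM, between 50000 nM and 200000 nM. The estimate means a step of a number no higher from compound 1 to compound 4 (the limit leaves the size open), expected to stay within the scatter.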

Compound 4, minimum cytotoxic concentration: > 100000 nM
Compound 4: a limit, no number; the forecaster's own chance of this, stated with the estimate: 70%; the middle value sits exactly at the limit.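

In this assay compound 4 gives > 100000 nM, which is a limit and not a number. The steps to compound 4 from compound 1 and from compound 3 therefore cannot be read, as both ends of each are limits. The compounds shown leave open whether compound 1, compound 3 and compound 4 differ at all in this read-out.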